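The source may report more compounds than this note shows. Statements on the series, on what has been measured and on what is new or still open speak of the compounds shown alone.

For the measured compounds named here, compound 3 `COc1ncc(C(F)(F)F)cc1CO[C@H]1[C@H](C(C)(C)C)[C@@H](C(=O)O)N(C(=O)[C@@H]2CCCCO2)[C@H]1c1ccccc1C(C)C` stands at the low end of the three numbers measured so far. In an assay on cells with Cystic fibrosis transmembrane conductance regulator variant F508del (Homo sapiens) as the target, read by voltage clamp, with a stated time of 24 h, in the presence of a further agent that is not named here (on this read-out lower numbers stand for an effect already at smaller amounts and higher numbers for an effect only at larger amounts of compound), compound 3 gives 35 nM, the lowest of the three. Compound 1 `COc1ncc(C(F)(F)F)cc1CO[C@H]1[C@H](C(C)(C)C)[C@@H](C(=O)O)N(C(=O)[C@@H]2CCCCO2)[C@H]1c1ccccc1` gives 213 nM, and compound 2 `COc1ncc(C(F)(F)F)cc1CO[C@H]1[C@H](C(C)(C)C)[C@@H](C(=O)O)N(C(=O)[C@H]2CCCCO2)[C@H]1c1ccccc1` gives 346 nM; a 1.6-fold higher number from compound 1 to compound 2 (0.21 log units; within the scatter), which fits (the fact that compounds 1 and 2 differ only in the configuration as drawn). Going by the values given here, the step that bears on the change ahead is the one from compound 1 to compound 3: a 6.1-fold lower number from compound 1 to compound 3 (0.78 log units; beyond the scatter), so adding the isopropyl group lowered the number by a modest amount. Compound 4 `COc1ncc(C(F)(F)F)cc1CO[C@H]1[C@H](C(C)(C)C)[C@@H](C(=O)O)N(C(=O)[C@@H]2CCCCO2)[C@H]1c1ccccc1Cl` differs from compound 3 in one place: chloro in place of isopropyl on an aromatic carbon. Among the compounds with values here, no measured pair sets chloro against isopropyl or against hydrogen, so the only guidance is that removing the isopropyl altogether, as in compound 1, raised the number. Chloro keeps a group on that aromatic carbon, though a smaller one. A number between those of compound 3 and compound 1 is therefore expected for compound 4, with a 2.0-fold higher number from compound 3 to compound 4 (0.30 log units; within the scatter). The estimate for compound 4 is 70 nM, with a range from 30 nM to 170 nM.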

Compound 4, half-maximal effective concentration: 222 nM
Estimate against measurement, compound 4: 3.2-fold (0.50 log units) below; the measured number lies above the stated range.
By their numbers in this assay, from the lowest: compound 3; then compounds 1, 4 and 2 (each within the scatter of the next).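

In this assay the chloro group does not stand in for the isopropyl group on this aromatic carbon, as a 6.3-fold higher number from compound 3 to compound 4 (0.80 log units; beyond the scatter) shows. Set against hydrogen at the same place, chloro gives a 1.0-fold higher number from compound 1 to compound 4 (0.02 log units; within the scatter) and so cannot be told apart from it, which means that having just any group there does not bring the lower number of compound 3; of the three substituents shown, only isopropyl does. Nothing given here accounts for why isopropyl and chloro part in this way.

The compounds shown leave open how methyl, ethyl, tert-butyl or cyclopropyl would read on this aromatic carbon, and so whether the lower number belongs to isopropyl alone. They also leave open whether isopropyl would lower the number in the same way with the configuration of compound 2.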